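The compounds below may be only part of what the source reports. "The series", "measured", "known", "first", "only" and "open" are said of these compounds alone.

Measured so far in a functional assay on A549 cells (Homo sapiens) for antiproliferative activity, read by MTT assay; a lower number here means a stronger inhibitor, a higher number a weaker inhibitor:
Compound 1 `O=C(OCCCl)N1CCCc2cc(S(=O)(=O)N3CC(c4ccccc4)NC3=O)ccc21` gives > 20000 nM as a limit of the assay
Compound 2 `NC(=O)N1CCCc2cc(S(=O)(=O)N3CC(c4ccccc4)NC3=O)ccc21` gives 2540 nM as a measured number

Going by the values given here, compound 2 holds the only number, since the other result is a limit. Compound 3 `O=C(CCl)NC(=O)N1CCCc2cc(S(=O)(=O)N3CC(c4ccccc4)NC3=O)ccc21` differs from compound 2 as follows: (chloromethyl)carbonyl in place of hydrogen on an amide-type nitrogen with the rest unchanged. Among the compounds with values here, the one measured step at this carbonyl carbon is an at least 7.8-fold lower number from compound 1 to compound 2 (0.89 log units; beyond the scatter) and it shows that the value can move well beyond the scatter here. Within the data shown here, a step of similar size is therefore expected in this assay with a lower number thought more likely, although no measured step fixes the direction. The expected change is a 3.2-fold lower number from compound 2 to compound 3 (0.50 log units; beyond the scatter) with wide uncertainty. The estimated value for compound 3 is 800 nM with an expected range from 120 nM to 6000 nM for now.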

Compound 3, half-maximal inhibitory concentration: 449 nM
The estimate for compound 3 lay 1.8-fold (0.25 log units) above the measured number; the measured number falls inside the stated range.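

In this assay, the amide-type nitrogen accepts (chloromethyl)carbonyl in place of hydrogen, with a 5.7-fold lower number from compound 2 to compound 3 (0.75 log units; beyond the scatter). Going by these compounds alone, this gives the first measured direction at that nitrogen, where earlier the only step lay on the carbonyl carbon. The step with ((chloromethyl)carbonyl)amino in place of 2-chloroethoxy, an at least 44-fold lower number from compound 1 to compound 3 (1.64 log units; beyond the scatter), is only a bound, as the value of compound 1 is a limit: the limit of > 20000 nM in this assay, at which 1 of the 3 values shown sits.

The compounds shown do not separate the contribution of the chlorine from that of the added carbonyl. An acetyl group on the same nitrogen, or a longer chloroalkyl chain on that carbonyl, would address this.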